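Turning Two Stereo Elements on a Low-Toxicity Compound

The source may hold more compounds than are shown below. What is called first, only, known or untested is meant among the compounds shown, and "the series" means these compounds.

In an ADME assay on HFF cells (Homo sapiens) for cytotoxicity, read by neutral red uptake (on this read-out higher numbers stand for lower toxicity in this test and lower numbers for higher toxicity in this test), compound 1 `Nc1nc2c(ncn2/C=C2\C[C@@H]2[C@@H](O)CO)c(=O)[nH]1` gives > 300000 nM as its reading, and this is a limit of the assay, not a number. Compound 1 thus stands at the limit of > 300000 nM in this assay, at which 1 of the 2 values shown sits, and has no exact value. Compound 2 `Nc1ncnc2c1ncn2/C=C1/C[C@H]1[C@@H](O)CO`, a relative with a different structure, gives 194000 nM as a true number in this assay and so offers a second reference.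

Compound 3 `Nc1nc2c(ncn2/C=C2/C[C@@H]2[C@H](O)CO)c(=O)[nH]1` has not yet been measured. Going by the values given here, its difference from compound 1 (the two compounds have the same atoms and bonds and differ only in configuration as drawn: 2 of 3 stereo elements differ; a stereocentre at a saturated chain carbon is drawn R in compound 1 and S in compound 3; a double bond is drawn E in compound 1 and Z in compound 3) is one of configuration alone, with a stereocentre at a saturated chain carbon going from R to S and a double bond going from E to Z. No measured pair here shows what such a change does, so no step beyond the usual scatter is expected, and no direction can be named. The estimated step of a number no higher from compound 1 to compound 3 (the limit leaves the size open) is expected to be small. Compound 3 is estimated at 300000 nM in a range from 120000 nM to 500000 nM on this read-out, and the result may well arrive as a limit again.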

Compound 3, half-maximal cytotoxic concentration: > 300000 nM
Compound 3: no number, only a limit (the forecaster's own chance of this, stated with the estimate: 60%); the middle value lies on the limit itself.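

In this assay compound 1 and compound 3 both give a limit rather than a number, so no step between them can be read: the limit of > 300000 nM in this assay, at which 2 of the 3 values shown sit.

The compounds shown leave open where the true readings of compound 1 and compound 3 lie, and whether turning the stereocentre or the double bond alone would change the reading.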